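Carbamoyl in place of formyl on the shared core

A few compounds are considered here, and "the series" means these few. Any claim that something is new, unique, unknown or untested is made for them only; others in the source may bear on it.

Two compounds have numbers in a functional assay on CHO cells for antagonist activity at C-X-C chemokine receptor type 3 (Homo sapiens), read by GTPgammaS binding, with a stated time of 30 min; on this read-out lower numbers stand for stronger inhibition and higher numbers for weaker inhibition. Compound 1 `O=C1CCC(c2cccnc2)(C2CCN(Cc3ccc(Br)cc3)CC2)C(=O)N1` gives 1000 nM in this assay. Compound 2 `O=CN1CCCC(c2ccccc2)(C2CCN(Cc3ccc(Br)cc3)CC2)C1` gives 150 nM, the lowest of the two numbers, and its gap to compound 1 is beyond the scatter; the two differ in more than one place, so only the values are noted. Compound 3 `NC(=O)N1CCCC(c2ccccc2)(C2CCN(Cc3ccc(Br)cc3)CC2)C1` is not yet measured. It differs from compound 2 by amino in place of hydrogen on a carbonyl carbon, or formyl to carbamoyl one bond further out. Among the compounds with values here, no measured pair shows this change, so a step within the scatter is expected, namely a 1.3-fold lower number from compound 2 to compound 3 (0.10 log units; within the scatter). Compound 3 is estimated at 120 nM, ranging from 40 nM to 400 nM.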

Compound 3, half-maximal inhibitory concentration: 250 nM
Compound 3: middle estimate off by 2.1-fold (0.32 log units), on the low side; the range from low to high includes it.
By their numbers in this assay, from the lowest: compounds 2 and 3 (each within the scatter of the next); then compound 1.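

In this assay, amino in place of hydrogen on a carbonyl carbon whose other neighbour is the amide-type nitrogen in a ring, the change from formyl to carbamoyl, gives a 1.7-fold higher number from compound 2 to compound 3 (0.22 log units; within the scatter). On this one pair, the position accepts the amino and its added hydrogen-bond donor with no step beyond the scatter. Nothing available bears on why the values stay this close. Within the data shown here, still open is how a dimethylamino or a methyl group on the same carbonyl carbon would read, and whether the outcome would hold on a core other than the one shared by compound 2 and compound 3.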